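Swapping a Methoxy for a Trifluoromethyl on a Weak Inhibitor

This account rests on a few compounds, and the source may have more. Where it says the series, first, only, none or still open, it means among the compounds named here.

Compound 1, `COc1ccc(N2CCCC2)c(C(=O)Nc2ccc(CNC(=O)OCc3cccnc3)cc2)c1`, was tested in a toxicity assay on WI-38 cells (Homo sapiens) for inhibition, read by MTT assay, with a stated time of 72 h; a higher number here means a weaker inhibitor, a lower number a stronger inhibitor. In this assay, for the measured compounds named here, compound 1 gives 35600 nM, the only numerical value among the two compounds measured so far. Compound 2, `O=C(NCc1ccc(NC(=O)c2cccc(F)c2N2CCCC2)cc1)OCc1cccnc1`, reaches only the limit of the assay, > 100000 nM, so no number is known for it. That is the limit of > 100000 nM in this assay, at which 1 of the 2 values shown sits. Going by the values given here, compound 1 therefore stands as the sole compound with a measured number, and that number already points to weak inhibition.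

Compound 3, `O=C(NCc1ccc(NC(=O)c2cc(C(F)(F)F)ccc2N2CCCC2)cc1)OCc1cccnc1`, has not been measured. It differs from compound 1 by one change: trifluoromethyl in place of methoxy on an aromatic carbon. Among the compounds with values here, no step between two measured compounds that differ in one place is available, so the size of this step cannot be read from the data. The step of a 1.3-fold higher number from compound 1 to compound 3 (0.10 log units; within the scatter) is expected to be small, none beyond the usual scatter. Compound 3 is estimated at 45000 nM, within 15000 nM to 140000 nM.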

Compound 3, half-maximal inhibitory concentration: > 100000 nM
Compound 3: no number, only a limit; the forecaster's own chance of this, stated with the estimate: 35%; at least 2.2-fold (0.34 log units) between middle value and limit.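

In this assay, trifluoromethyl in place of methoxy, on an aromatic carbon para to a pyrrolidin-1-yl group, gives an at least 2.8-fold higher number from compound 1 to compound 3 (0.44 log units; beyond the scatter). For the compounds shown here, this is the first step between two measured compounds that differ in one place, and it shows that a change at this position can move the read-out beyond the scatter, towards weaker inhibition. Compound 3 carries a limit and not a number, so the step gives only a minimum size, and how far the change really reaches stays unknown: the limit of > 100000 nM in this assay, at which 2 of the 3 values shown sit.

Going by these compounds, whether the shift comes from losing methoxy or from gaining trifluoromethyl stays open, and a methyl group or an amine on the same carbon would help to separate the two. The compounds shown also leave open whether the same swap on another aromatic carbon would act in the same way.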